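The source may hold more compounds than are shown below. What is called first, only, known or untested is meant among the compounds shown, and "the series" means these compounds.

Compound 1 `Cc1cc(NC(C)C)nc(SCc2nc3ccccc3[nH]2)n1`: in a functional assay on ECa-109 cells (Homo sapiens) for cytotoxicity, read by MTT assay, with a stated time of 72 h (a lower number here means a stronger inhibitor, a higher number a weaker inhibitor), compound 1 gives > 100000 nM, which is a limit of the assay and not a number.
Compound 2 `Cc1cc(N(C)Cc2ccccc2)nc(SCc2nc3ccccc3[nH]2)n1`: in this assay compound 2 gives > 100000 nM, again a limit rather than a number.

Compound 2 thus stands at the limit, as do all values shown (the limit of > 100000 nM in this assay, at which 2 of the 2 values shown sit). Among the measured compounds shown here, the one measured step, a step that the two limits leave unreadable from compound 1 to compound 2, cannot be read in size or direction. Compound 3 `Cc1cc(Nc2ccc(F)cc2)nc(SCc2nc3ccccc3[nH]2)n1` differs from compound 2 by (4-fluorophenyl)amino in place of benzyl(methyl)amino on an aromatic carbon. For the measured compounds named here, no measured step bears readably on this change, so no step beyond the scatter is expected in this assay. Compound 3 is therefore expected to give 100000 nM, with a range from 30000 nM to 300000 nM. The expected step is a number no higher from compound 2 to compound 3 (the limit leaves the size open), most likely again only a limit.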

Compound 3, half-maximal inhibitory concentration: 69500 nM
Compound 3: middle estimate off by 1.4-fold (0.16 log units), on the high side; the range from low to high includes it.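

In this assay, among the compounds shown here, compound 3 gives 69500 nM, the only number among the three compounds, with (4-fluorophenyl)amino at this position. The readable steps are an at least 1.4-fold lower number from compound 2 to compound 3 (0.15 log units; that floor lies within the scatter) and an at least 1.4-fold lower number from compound 1 to compound 3 (0.15 log units; that floor lies within the scatter). Neither floor alone shows a real change, and the true size of both steps stays open: the limit of > 100000 nM in this assay, at which 2 of the 3 values shown sit.

The compounds shown leave open how plain phenylamino, without the fluorine, would read in this assay. Going by these compounds, a morpholine or a carboxylic acid-bearing amine at this position is equally open.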